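This account rests on a few compounds, and the source may have more. Where it says the series, first, only, none or still open, it means among the compounds named here.

Series notes. Compound 1 `Oc1cccc(-c2cc(-c3cccnc3)nc(-c3cccc(Cl)c3)c2)c1` carries a pyridin-3-yl on the shared core. In an ADME assay on HEK293 cells (Homo sapiens) for cytotoxicity, read by CCK-8 assay and cell counting, with a stated time of 2 days (a higher number here means a weaker inhibitor, a lower number a stronger inhibitor), compound 1 gives "not determined" (no result reported), so no number places it on the scale; the same holds for compound 2 `Oc1cccc(-c2cc(-c3cccnc3)nc(-c3ccccc3Cl)c2)c1`, which in this assay also gives "not determined" (no result reported). Within the data shown here, the only figure comes from compound 3 `Oc1cccc(-c2cc(-c3ccc(Cl)cc3)nc(-c3cccnc3)c2)c1`, which in this assay gives 39500 nM, a weak effect. Compound 4 `Oc1cccc(-c2cc(-c3cccc(Cl)c3)nc(-c3ccco3)c2)c1` differs from compound 1 by furan-2-yl in place of pyridin-3-yl on an aromatic carbon. Among the measured compounds shown here, with no number for compound 1, no step size can be computed; the one available value suggests the whole series sits at the weak end, and the exchange of one small aromatic ring for another is expected to leave compound 4 within the scatter of that level rather than shift it clearly in either direction. Compound 4 is expected near 40000 nM in this assay, in the range 15000 nM to 100000 nM.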

Compound 4, half-maximal inhibitory concentration: 2530 nM
Estimate against measurement, compound 4: 16-fold (1.20 log units) above; measured number below the stated range.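

In this assay, among these compounds, compound 1 gives "not determined" (no result reported) and no step to compound 4 can be read. The compounds shown leave open whether furan-2-yl in place of pyridin-3-yl shifts the value on the shared core. No measured evidence here bears on the result.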